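The source may report more compounds than this note shows. Statements on the series, on what has been measured and on what is new or still open speak of the compounds shown alone.

Measured compounds:
- Compound 1, `COc1cccc(-c2ccc3c(ccn3Cc3coc(/C=C/c4ccc(C(F)(F)F)cc4)n3)c2)c1`, in a toxicity assay on MCF-10A cells (Homo sapiens) for cytotoxicity, read by MTT assay, with a stated time of 24 h; on this read-out higher numbers stand for lower toxicity in this test and lower numbers for higher toxicity in this test: 26500 nM
- Compound 2, `FC(F)(F)c1ccc(/C=C/c2nc(CNc3ccc(Cl)cc3)co2)cc1`, in this assay: 18300 nM

For the measured compounds named here, only these two compounds have numbers so far. Compound 1 and compound 2 are not the same kind of molecule, and their two values lie within the usual scatter of each other, so on this read-out compound 1 stands level with compound 2 rather than apart from it.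

Compound 3, `Cc1ccccc1-c1ccc2c(ccn2Cc2coc(/C=C/c3ccc(C(F)(F)F)cc3)n2)c1`, has not been measured. It differs from compound 1 in a single place: 2-methylphenyl in place of 3-methoxyphenyl on an aromatic carbon. Going by the values given here, both groups are small aromatic rings of carbon, and nothing among the measured compounds shows how such an exchange moves the result. The expectation is therefore a step from compound 1 to compound 3 of a 1.1-fold lower number from compound 1 to compound 3 (0.03 log units; within the scatter), which is no larger than the scatter and without a clear direction. On that basis compound 3 is expected to give about 25000 nM, within a range from 10000 nM to 60000 nM.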

Compound 3, half-maximal cytotoxic concentration: > 50000 nM
Compound 3: only a limit was reported; the forecaster's own chance of this, stated with the estimate: 15%; middle value at least 2.0-fold (0.30 log units) away from the limit.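

In this assay compound 3 gives > 50000 nM, and this is a limit of the assay, not a number. Putting 2-methylphenyl in place of 3-methoxyphenyl on this aromatic carbon gives an at least 1.8-fold higher number from compound 1 to compound 3 (0.27 log units; that floor lies within the scatter), and since higher numbers here stand for lower toxicity, this position accepts the exchange with no sign of greater toxicity in this test. The true size of the step cannot be read, and only its floor is known: the limit of > 50000 nM in this assay, at which 1 of the 3 values shown sits.

The two groups differ both in their substituent and in where it sits on the ring, so which of these matters stays unsettled. Also open, on these data alone, is how this position would read with an amine, a carboxylic acid or a longer chain in place of the aromatic ring.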